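Swapping a butylamino chain for a methylpiperazine ring

The source may hold more compounds than are shown below. What is called first, only, known or untested is meant among the compounds shown, and "the series" means these compounds.

Of the compounds shown here, two have been measured in a functional assay on SW480 cells (Homo sapiens) for inhibition, read by luminescence and resazurin assay, with a stated time of 3 days; on this read-out lower numbers stand for stronger inhibition and higher numbers for weaker inhibition. Compound 1 `CCNc1nc(NCc2ccc(C(=O)Nc3ccc(F)cc3)cc2)c2ccccc2n1` gives 2500 nM. Compound 2 `CCCCNc1nc(NCc2ccc(C(=O)Nc3ccc(F)cc3)cc2)c2ccccc2n1` gives 1000 nM. Among the measured compounds shown here, the only step recorded so far, a 2.5-fold lower number from compound 1 to compound 2 (0.40 log units; beyond the scatter), comes from lengthening the alkyl chain on the amino group. On the numbers shown, compound 2 stands lowest of the two, and its nearest neighbour is compound 1.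

Compound 3 `CC1CN(c2nc(NCc3ccc(C(=O)Nc4ccc(F)cc4)cc3)c3ccccc3n2)CCN1` differs from compound 2 by 3-methylpiperazin-1-yl in place of butylamino on an aromatic carbon. For the measured compounds named here, the single measured step bears on this change only loosely: it shows that a bulkier substituent on that amino nitrogen went along with a lower number, but it says nothing about closing the chain into a ring or about adding a second nitrogen. Going by the values given here, with no closer precedent, the estimate for compound 3 in this assay is 1500 nM, with a range from 400 nM to 6000 nM. The expected step of a 1.5-fold higher number from compound 2 to compound 3 (0.18 log units; within the scatter) is therefore one that may well fall within the usual scatter, and the wide range reflects how little the existing data constrain it.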

Compound 3, half-maximal inhibitory concentration: 3200 nM
For compound 3 the middle estimate is 2.1-fold (0.33 log units) below the measured one; the measured number falls inside the stated range.
By their numbers in this assay, from the lowest: compound 2; then compounds 1 and 3 (each within the scatter of the next).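

In this assay, 3-methylpiperazin-1-yl on the aromatic carbon between two ring nitrogen atoms gives a 3.2-fold higher number from compound 2 to compound 3 (0.51 log units; beyond the scatter) and so does not keep the lower number of compound 2, something the earlier pair, which held only open chains at this place, could not show. Set against the shorter chain, the same ring gives a 1.3-fold higher number from compound 1 to compound 3 (0.11 log units; within the scatter) and leaves compound 3 and compound 1 indistinguishable on this read-out, so at this place the two compounds show that the butylamino chain alone stands apart from the others. No independent measurement is at hand that speaks to what lies behind these steps.

The swap closes a ring, brings in a second nitrogen and adds a methyl all at once, and the compounds shown do not separate these three changes. From the compounds shown here alone, whether unsubstituted piperazine, morpholine or a longer chain such as hexylamino on this carbon would come closer to compound 2, or pass it, remains open.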